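Difluoromethyl to trifluoromethoxy on the biaryl series

The source may hold more compounds than are shown below. What is called first, only, known or untested is meant among the compounds shown, and "the series" means these compounds.

Measured so far:
compound 1 `CC(C)c1ccccc1-c1ccc2[nH]ncc2c1`: 514 nM
compound 2 `FC(F)c1ccccc1-c1ccc2[nH]ncc2c1`: 2200 nM

In an assay on CHO-TREX cells for antagonist activity at transient receptor potential cation channel subfamily A member 1 (Homo sapiens), read by FLIPR and calcium flux, with a stated time of 10 min (a higher number here means a weaker inhibitor, a lower number a stronger inhibitor), compound 1 gives 514 nM and compound 2 gives 2200 nM. For the measured compounds named here, compound 2 thus carries the highest number of the two; the one step known, a 4.3-fold higher number from compound 1 to compound 2 (0.63 log units; beyond the scatter), takes it beyond the scatter from compound 1. Compound 3 `FC(F)(F)Oc1ccccc1-c1ccc2[nH]ncc2c1` is not yet measured. It differs from compound 2 by trifluoromethoxy in place of difluoromethyl on an aromatic carbon. Going by the values given here, the only measured step concerns a different exchange at the same aromatic carbon, so it bears on this one only loosely: it shows that a change of the group at that carbon can move the number by a modest amount in this assay. For compound 3 a small step back toward the number of compound 1 is expected, a 1.8-fold lower number from compound 2 to compound 3 (0.26 log units; within the scatter), with wide uncertainty. The estimate for compound 3 in this assay is 1200 nM, in the range 400 nM to 4000 nM.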

Compound 3, half-maximal inhibitory concentration: 3430 nM
Estimate against measurement, compound 3: 2.9-fold (0.46 log units) below; the measured number falls inside the stated range.
By their numbers in this assay, from the lowest: compound 1; then compounds 2 and 3 (each within the scatter of the next).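

In this assay the exchange at this aromatic carbon gives a 1.6-fold higher number from compound 2 to compound 3 (0.19 log units; within the scatter) and so leaves compound 2 and compound 3 unresolved, even though trifluoromethoxy brings a hydrogen-bond acceptor that difluoromethyl does not have. Measured against isopropyl, the same group gives a 6.7-fold higher number from compound 1 to compound 3 (0.82 log units; beyond the scatter) and so, among the three compounds, isopropyl alone stands apart, with both fluorinated groups giving higher numbers than compound 1. No measurement is available that explains either step.

Still open, from the compounds shown here alone, is whether an amine, a methoxy group or a longer alkyl chain at this carbon would fall with compound 1 or with compound 2 and compound 3 in this assay. Also open, going by these compounds, is whether these exchanges would give similar steps at another aromatic carbon of the same ring.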